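This account rests on a few compounds, and the source may have more. Where it says the series, first, only, none or still open, it means among the compounds named here.

Measured so far in an assay on isolated protein for inhibition of leukotriene B4 receptor 1 (Homo sapiens), tested at 10 uM; on this read-out higher numbers stand for more inhibition at the one concentration tested (going by the name of the read-out) and lower numbers for less inhibition:

- compound 1 `CC(=O)c1cc(CC(C)O)c(OCCCCC#N)cc1O`: 10%
- compound 2 `C=CCc1cc(C(C)=O)c(O)cc1OCCCCCCCCC#N`: 86%
- compound 3 `CCc1cc(C(C)=O)c(O)cc1OCCCCC(C)(C)C#N`: 79%

Compound 3 holds the second highest of the three numbers. Its nearest neighbour is compound 2, whose number is higher by an amount within the scatter, so no order between compound 2 and compound 3 can be read from this assay. Going by the values given here, its furthest neighbour is compound 1, whose number lies far lower, beyond the scatter; no single-change step connects compound 1 to either of the others, so only the two values themselves can be compared.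

Compound 4 `CCc1cc(C(C)=O)c(O)cc1OCCCCCn1cncn1` is not yet measured. Its structure differs from compound 3 in one place: (1H-1,2,4-triazol-1-yl)methyl in place of 1-cyano-1-methylethyl on a saturated chain carbon, four bonds along the chain from an oxygen on an aromatic ring.

Among the compounds with values here, no step between measured compounds isolates this change, so its size is not anchored. Both compound 2 and compound 3 carry a nitrile at the chain end; compound 4 drops it for the aromatic ring named above. The expected step in this assay, from compound 3 to compound 4, is a number 19 percentage points lower from compound 3 to compound 4 (beyond the scatter), a moderate fall, but with wide uncertainty. Compound 4 is thus estimated at 60%, expected between 25% and 85%.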

Compound 4, a percentage reported as inhibition, at one concentration (the size of the read-out at that concentration, not a potency): 82%
The estimate for compound 4 lay 22 percentage points below the measured number; the range from low to high includes it.
By their numbers in this assay, from the lowest: compound 1; then compounds 3, 4 and 2 (each within the scatter of the next).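

For this assay the exchange of 1-cyano-1-methylethyl for (1H-1,2,4-triazol-1-yl)methyl on a saturated chain carbon, four bonds along the chain from an oxygen on an aromatic ring, reads a number 3 percentage points higher from compound 3 to compound 4 (within the scatter) and leaves no order between the two compounds. This pair therefore shows that a nitrile at this place is not required to hold the number, since the entering group carries none and brings one five-membered aromatic ring with 3 hetero atoms instead. Nothing available explains why the number holds across this exchange.

Still open, from the compounds shown here alone, is whether an amine, a carboxylic acid or an imidazole at the same place would hold the number as well. Going by these compounds alone, also open is whether the triazole keeps its number on a longer chain, and a read-out at one concentration gives no potency for either compound.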